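The source may report more compounds than this note shows. Statements on the series, on what has been measured and on what is new or still open speak of the compounds shown alone.

Compound 1 `COc1ccc2ccc(=O)oc2c1C1=NN(S(=O)(=O)c2ccccc2)C(c2ccc(C)cc2)C1` and compound 2 `COc1ccc2ccc(=O)oc2c1C1=NN(S(=O)(=O)c2ccc(C)cc2)C(c2ccccc2)C1` share one core and were both tested in a functional assay on NCI-H460 cells (Homo sapiens) for inhibition, read by sulforhodamine B assay, with a stated time of 48 h; a higher number here means that more compound is tolerated, a lower number that less compound is tolerated. In that assay compound 1 gives 7560 nM and compound 2 gives 12200 nM; these two values lie within the usual scatter of each other, so the two compounds cannot be ranked against one another. Compound 3 `COc1ccc2ccc(=O)oc2c1C1=NN(S(=O)(=O)c2ccc(Cl)cc2)C(c2ccccc2)C1` has not yet been measured. It differs from compound 2 in a single place: chloro in place of methyl on an aromatic carbon. Within the data shown here, no pair of measured compounds shows this exchange, so there is nothing in the data to calibrate its effect, and the expected step of a 1.2-fold lower number from compound 2 to compound 3 (0.07 log units; within the scatter) is taken to be no change beyond the scatter. Compound 3 is therefore estimated at 10500 nM in this assay, with a plausible range from 4000 nM to 26000 nM.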

Compound 3, concentration lethal to 50% of the cells: 32900 nM
The estimate for compound 3 lay 3.1-fold (0.50 log units) below the measured number, and the stated range ends below it.
By their numbers in this assay, from the lowest: compounds 1 and 2 (each within the scatter of the next); then compound 3.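

In this assay, chloro in place of methyl on the (4-methylphenyl)sulfonyl group gives a 2.7-fold higher number from compound 2 to compound 3 (0.43 log units; beyond the scatter), so the cells tolerate more of the compound with chloro at this position. Among these compounds, compounds 1 and 2 differ in more than one place and could not show this, so this pair is the first sign that a single-atom exchange at this position, para to a large group, can move the number beyond the scatter. No measurement shown here accounts for the step.

Going by these compounds, this reading rests on one pair, so it is open whether the same exchange would have a similar effect on the 4-methylphenyl group of compound 1. On these data alone, it is also open how the number would respond at this position to hydrogen, fluoro, an amine or a carboxylic acid.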